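The compounds below may be only part of what the source reports. "The series", "measured", "known", "first", "only" and "open" are said of these compounds alone.

- Compound 1 `C/C=C(\C)C(=O)O[C@H]1C=CC(=O)O[C@H]1CCC(=O)[C@H](C)O`: 24000 nM
- Compound 2 `C/C=C(\C)C(=O)O[C@H]1C=CC(=O)O[C@H]1COC(=O)[C@H](C)O`: 13000 nM

Within the data shown here, in a functional assay on M14 cells (Homo sapiens) for antiproliferative activity, read by sulforhodamine B assay, with a stated time of 48 h (on this read-out higher numbers stand for weaker inhibition and lower numbers for stronger inhibition), compound 2 gives 13000 nM, which stands within the scatter of the only other number, that of compound 1. Compound 3 `C/C=C(\C)C(=O)O[C@H]1C=CC(=O)O[C@H]1CNC(=O)[C@H](C)O` has ((1-hydroxyethyl)carbonyl)amino in place of ((1-hydroxyethyl)carbonyl)oxy on a saturated chain carbon bound to a saturated ring carbon. Among the measured compounds shown here, one measured step bears on this place, a 1.8-fold lower number from compound 1 to compound 2 (0.27 log units; within the scatter), and it stayed within the scatter. No shift beyond the scatter is therefore expected in this assay, and the estimated step is a 1.2-fold higher number from compound 2 to compound 3 (0.09 log units; within the scatter). Compound 3 is expected at 16000 nM, with an estimated range of 6000 nM to 40000 nM.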

Compound 3, half-maximal inhibitory concentration: 28000 nM
Beside the measured number, compound 3's estimate is 1.8-fold (0.24 log units) below it, within the range that was stated.
By their numbers in this assay, from the lowest: compounds 2, 1 and 3 (each within the scatter of the next, the first and the last beyond it).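

In this assay, among these compounds, the change to ((1-hydroxyethyl)carbonyl)amino gives a 2.2-fold higher number from compound 2 to compound 3 (0.33 log units; beyond the scatter) and so produces the first modest step beyond the scatter at this place, while the comparison with the ((1-hydroxyethyl)carbonyl)methyl group gives a 1.2-fold higher number from compound 1 to compound 3 (0.07 log units; within the scatter) and stays within it. On a saturated chain carbon bound to a saturated ring carbon, the oxy and amino links can thus be told apart, but the methyl and amino links cannot. No evidence given here accounts for this difference. As far as these compounds go, what a carboxylic acid or a longer chain would give at this place remains open.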